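Adding a phenyl ring to a weak triazine inhibitor

The compounds below may be only part of what the source reports. "The series", "measured", "known", "first", "only" and "open" are said of these compounds alone.

Measured so far:
- Compound 1 `CCCc1nc(C)c2cnnc(O)n12`: 56800 nM
- Compound 2 `Cc1nc(C(C)(C)C)n2c(O)nncc12`: 31000 nM

In a functional assay for inhibition, with Homo sapiens as the target (a higher number here means a weaker inhibitor, a lower number a stronger inhibitor), compound 1 gives 56800 nM, the highest of the two numbers. Among the compounds with values here, the only neighbour is compound 2, and the change a 1.8-fold lower number from compound 1 to compound 2 (0.26 log units; within the scatter) is a swap of one alkyl group for another on the shared core, not a change at the site now in question.

Compound 3 `CCCc1nc(C)c2c(-c3ccccc3)nnc(O)n12` differs from compound 1 by phenyl in place of hydrogen on an aromatic carbon. Within the data shown here, no measured step touches this position, so the one step available gives no guide to size or direction; it shows only that a change elsewhere on the core left the number inside the scatter.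

With nothing more to lean on, a modest gain at most is expected, and compound 3 is estimated at 20000 nM, within 5000 nM to 80000 nM, corresponding to an expected 2.8-fold lower number from compound 1 to compound 3 (0.45 log units; beyond the scatter).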

Compound 3, half-maximal inhibitory concentration: > 48000 nM
Compound 3 gave a limit, no number; the forecaster's own chance of this, stated with the estimate: 10%; middle value at least 2.4-fold (0.38 log units) away from the limit.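

The result for compound 3, > 48000 nM, is a limit and not a number. The step from compound 1 to compound 3 therefore cannot be read. The compounds shown leave open how far, and in which direction, phenyl in place of hydrogen on this aromatic carbon moves the number.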